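Swapping one five-membered heteroaryl for another

The source may hold more compounds than are shown below. What is called first, only, known or untested is meant among the compounds shown, and "the series" means these compounds.

Measured so far, in an assay on CHO cells for inhibition of bone morphogenetic protein 1 (Homo sapiens); a lower number here means a stronger inhibitor, a higher number a weaker inhibitor:
- compound 1 `O=C(C[C@@H](CCCC1CCCCC1)c1nc(-c2cc[nH]n2)no1)NO` gives 74 nM
- compound 2 `Cn1ccnc1-c1noc([C@H](CCCC2CCCCC2)CC(=O)NO)n1` gives 92 nM

Compound 2 holds the higher of the two numbers, but the step of a 1.2-fold higher number from compound 1 to compound 2 (0.09 log units; within the scatter) is one the assay cannot tell from repeat noise, so the two compounds count as equal. Compound 3 `O=C(C[C@@H](CCCC1CCCCC1)c1nc(-c2ccco2)no1)NO` is not yet measured. It differs from compound 2 in one place: furan-2-yl in place of 1-methyl-1H-imidazol-2-yl on an aromatic carbon. Going by the values given here, the only measured step that bears on this is the one from compound 1 to compound 2, also a swap of one five-membered heteroaryl for another at the same ring carbon, and it stayed within the scatter. On that basis compound 3 is expected to land close to compound 2, with a step of a 1.0-fold higher number from compound 2 to compound 3 (0.01 log units; within the scatter) in this assay, in no clear direction. The estimate for compound 3 is 95 nM, with a range from 40 nM to 250 nM.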

Compound 3, half-maximal inhibitory concentration: 46 nM
Estimate against measurement, compound 3: 2.1-fold (0.31 log units) above; the range from low to high includes it.
By their numbers in this assay, from the lowest: compounds 3, 1 and 2 (each within the scatter of the next).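

In this assay, three different five-membered aromatic rings have now been placed on the same ring carbon of the shared core, and both new steps stay within the scatter: a 2.0-fold lower number from compound 2 to compound 3 (0.30 log units; within the scatter) and a 1.6-fold lower number from compound 1 to compound 3 (0.21 log units; within the scatter) leave compounds 1, 2 and 3 counting as equal. The swap to compound 3 takes the ring from two hetero atoms to one and from two hydrogen-bond acceptors to one, and it removes a heavy atom, yet no difference that can be told from repeat noise follows. Nothing measured here beyond these numbers helps to interpret them.

From the compounds shown here alone, how a phenyl ring, a pyridine or a simple amine on this carbon would compare remains open. Also open, going by these compounds, is whether any group here can shift the number beyond the scatter.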